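The compounds below may be only part of what the source reports. "The series", "measured", "known", "first", "only" and "open" are said of these compounds alone.

Measured so far in an ADME assay on Vero cells (Chlorocebus sabaeus) for cytotoxicity, read by MTT assay, with a stated time of 96 h; a higher number here means that more compound is tolerated, a lower number that less compound is tolerated:

- Compound 1 `C/C(=N\NC(N)=O)c1ccc2[nH]c(-c3ccc(C(F)(F)F)cc3)nc2c1`: > 100000 nM, a limit
- Compound 2 `C/C(=N\NC(N)=O)c1ccc2c(c1)nc(-c1ccc(Cl)cc1)n2C1CCCCC1`: > 100000 nM, a limit

Neither entry is a number, and compound 2 therefore has no exact place on the scale. Both compounds rest at the same limit, as the limit of > 100000 nM in this assay, at which 2 of the 2 values shown sit, shows. With only limits in hand, the data set no order between them.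

The next compound is compound 3 `C/C(=N\NC(N)=O)c1ccc2c(c1)nc(-c1ccc(C(F)(F)F)cc1)n2C1CCCCC1`, which differs from compound 2 in one place. Trifluoromethyl stands in place of chloro on an aromatic carbon, para to a large group, so 4-chlorophenyl becomes 4-(trifluoromethyl)phenyl: trifluoromethyl in place of chloro on an aromatic carbon.

Within the data shown here, no step between measured compounds is available to size this change directly. Among the measured compounds shown here, the expectation rests on compound 2 at > 100000 nM, which is a limit, and on the single swap. In this assay the expected step of an at least 1.1-fold lower number from compound 2 to compound 3 (0.04 log units; that floor lies within the scatter) is none beyond the usual scatter, with no direction favoured. The estimated value for compound 3 is 90000 nM, with an expected range of 40000 nM to 100000 nM.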

Compound 3, half-maximal cytotoxic concentration: > 100000 nM
Compound 3: only a limit was reported (the forecaster's own chance of this, stated with the estimate: 70%); at least 1.1-fold (0.04 log units) between middle value and limit.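

In this assay compound 3 gives > 100000 nM as a limit and not a number. Among these compounds, no step from compound 1 or compound 2 to compound 3 can be read, because all three sit at the same limit: the limit of > 100000 nM in this assay, at which 3 of the 3 values shown sit. As far as these compounds go, whether trifluoromethyl in place of chloro, or cyclohexyl in place of hydrogen on an aromatic nitrogen, changes the tolerated concentration in this assay stays open.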